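Urea-linked oxadiazoles: sulfamoyl to methanesulfonamido swap

The compounds below may be only part of what the source reports. "The series", "measured", "known", "first", "only" and "open" are said of these compounds alone.

Measured compounds:
compound 1 `CC(=O)Nc1ccc(S(=O)(=O)Nc2cccc(-c3nc(-c4ccc(NC(=O)c5cccnc5)cc4)no3)c2)cc1` with 5200 nM
compound 2 `NS(=O)(=O)c1ccc(NC(=O)Nc2cccc(-c3nc(-c4ccc(NC(=O)c5cccnc5)cc4Cl)no3)c2)cc1` with > 10000 nM

Two compounds of this series have been run in a functional assay on MDA-MB-231 cells (Homo sapiens) for antiproliferative activity, read by MTT assay, with a stated time of 72 h; on this read-out higher numbers stand for weaker inhibition and lower numbers for stronger inhibition. Compound 1 `CC(=O)Nc1ccc(S(=O)(=O)Nc2cccc(-c3nc(-c4ccc(NC(=O)c5cccnc5)cc4)no3)c2)cc1` gives a numerical value in this assay of 5200 nM. Compound 2 `NS(=O)(=O)c1ccc(NC(=O)Nc2cccc(-c3nc(-c4ccc(NC(=O)c5cccnc5)cc4Cl)no3)c2)cc1` returns only a limit in this assay, > 10000 nM, which is where it stands: at the limit of > 10000 nM in this assay, at which 1 of the 2 values shown sits, with no number to place it. Within the data shown here, no single-change step joins the two measured compounds, so nothing more than these two readings can be said of them together.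

Compound 3 `CS(=O)(=O)Nc1ccc(NC(=O)Nc2cccc(-c3nc(-c4ccc(NC(=O)c5cccnc5)cc4Cl)no3)c2)cc1` is the next compound in the line, and it differs from compound 2 in one place: methanesulfonamido in place of sulfamoyl on an aromatic carbon. Among the measured compounds shown here, since compound 2 gives only a limit in this assay, the step to compound 3 cannot be anchored to a measured number, and no measured step shows what this kind of exchange does. The step expected from compound 2 to compound 3, a step that the limit leaves unreadable from compound 2 to compound 3, is therefore set near the limit itself, with no clear direction beyond the scatter. For compound 3 the estimate in this assay is 12000 nM, within a range of 4000 nM to 40000 nM.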

Compound 3, half-maximal inhibitory concentration: 600 nM
For compound 3 the middle estimate is 20-fold (1.30 log units) above the measured one; the measured number lies below the stated range.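

At this aromatic carbon, para to a large group, the series now has its first readable single-place step in this assay: methanesulfonamido in place of sulfamoyl gives an at least 16-fold lower number from compound 2 to compound 3 (1.22 log units; beyond the scatter). The position is therefore sensitive to the group it carries, even though the two groups have the same hydrogen-bond donor and acceptor counts, neither brings a ring or a net charge, and the change turns the attachment to the ring from sulfur to nitrogen and adds a methyl on the sulfonyl. The full size of this step stays unknown, since the value of compound 2 is a limit and not a number: the limit of > 10000 nM in this assay, at which 1 of the 3 values shown sits.

The compounds shown do not separate the added methyl from the changed attachment, and an acetamido group or a plain amine at this carbon would be needed to tell how much of the step belongs to the sulfonamide nitrogen. Going by these compounds, it also remains open whether the same exchange holds outside the urea-linked, chloro-substituted compounds, as compound 1 differs from compound 3 in more than one place.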